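A few compounds are considered here, and "the series" means these few. Any claim that something is new, unique, unknown or untested is made for them only; others in the source may bear on it.

Three esters sharing one core have been measured in a functional assay on HCT-116 cells (Homo sapiens) for cytotoxicity, read by sulforhodamine B assay, with a stated time of 72 h; a higher number here means a weaker inhibitor, a lower number a stronger inhibitor. Compound 1 `C=C1C(=O)O[C@@H]2CC(C)=C([C@@H](C)CCCOC(C)=O)[C@@H](OC(=O)COc3cccc4cccnc34)[C@H]12` gives 12100 nM, compound 2 `C=C1C(=O)O[C@@H]2CC(C)=C([C@@H](C)CCCOC(C)=O)[C@@H](OC(=O)COc3cccc4[nH]nnc34)[C@H]12` gives 23700 nM, and compound 3 `C=C1C(=O)O[C@@H]2CC(C)=C([C@@H](C)CCCOC(C)=O)[C@@H](OC(=O)c3ccccc3F)[C@H]12` gives 21100 nM. Compound 3 cannot be told apart from the other two, and the remaining pair is no different, with a 2.0-fold higher number from compound 1 to compound 2 (0.29 log units; within the scatter).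

Compound 4 `C=C1C(=O)O[C@@H]2CC(C)=C([C@@H](C)CCCOC(C)=O)[C@@H](OC(=O)c3ccc(F)cc3)[C@H]12` has the same atoms as compound 3, joined differently: 4-fluorophenyl in place of 2-fluorophenyl on a carbonyl carbon. Here, 4-fluorophenyl stands in place of 2-fluorophenyl on a carbonyl carbon, and the rest of the molecule is unchanged.

Within the data shown here, no measured step tests this exchange directly, since no pair of measured compounds differs only in where the fluorine sits. The closest evidence comes from compound 3 and its two comparators, which differ in the whole group on the carbonyl carbon. Those exchanges gave only a 1.7-fold higher number from compound 1 to compound 3 (0.24 log units; within the scatter) and a 1.1-fold lower number from compound 2 to compound 3 (0.05 log units; within the scatter). With changes that large staying inside the scatter, the smaller exchange at hand is not expected to produce a step beyond it. The expected step is a 1.1-fold lower number from compound 3 to compound 4 (0.05 log units; within the scatter). Compound 4 is estimated at 19000 nM, with an expected range from 9500 nM to 38000 nM.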

Compound 4, half-maximal inhibitory concentration: 14900 nM
Beside the measured number, compound 4's estimate is 1.3-fold (0.11 log units) above it; low and high end bracket the measured number.
By their numbers in this assay, from the lowest: compounds 1, 4, 3 and 2 (each within the scatter of the next).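

In this assay, among these compounds, the exchange of 4-fluorophenyl for 2-fluorophenyl on a carbonyl carbon gives a 1.4-fold lower number from compound 3 to compound 4 (0.15 log units; within the scatter), the first reading of what moving the fluorine does with the atoms otherwise kept the same, and the two isomers cannot be told apart. The new compound also stays within the scatter of the two esters with the larger groups on the carbonyl carbon, with a 1.6-fold lower number from compound 2 to compound 4 (0.20 log units; within the scatter) and a 1.2-fold higher number from compound 1 to compound 4 (0.09 log units; within the scatter), so neither the place of the fluorine nor the exchange of the whole group has yet separated any of these esters. No measurement is available here that would explain the size of these steps.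

The compounds shown therefore leave open whether any group on this carbonyl carbon can move the number beyond the scatter, for instance a phenyl carrying an amine or a carboxylic acid, or a longer chain leading to the aromatic ring. They also leave open what a change elsewhere would do, since the acetate-bearing chain and the shared core are the same in all four compounds.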